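A Halogen Swap on the Aryl Ring and Microsomal Stability

The compounds below may be only part of what the source reports. "The series", "measured", "known", "first", "only" and "open" are said of these compounds alone.

Compound 1, `N#Cc1ccc(NCCNc2ncc(-c3ncc[nH]3)c(-c3ccc(Cl)cc3Cl)n2)nc1`: > 0.5 h
Compound 2, `FC(F)(F)c1ccc(NCCNc2ncc(-c3ncc[nH]3)c(-c3ccc(Cl)cc3Cl)n2)nc1`: > 0.5 h
Compound 3, `Nc1nc(NCCNc2ncc(-c3ncc[nH]3)c(-c3cc(F)ccc3Cl)n2)ccc1[N+](=O)[O-]`: > 0.5 h

In an ADME assay on microsomes from liver (Rattus norvegicus) for metabolic stability (on this read-out higher numbers stand for a longer-lived compound and lower numbers for a shorter-lived compound), compound 1 gives > 0.5 h, which is a limit of the assay rather than a number. Compound 2 gives > 0.5 h in this assay, again only a limit. Compound 3 gives > 0.5 h in this assay, also a limit. Within the data shown here, the one step between neighbours, a step that the two limits leave unreadable from compound 1 to compound 2, cannot be read because both ends are limits. Among the measured compounds shown here, compound 3 therefore stands where every value shown stands: at the limit of > 0.5 h in this assay, at which 3 of the 3 values shown sit, with no measured compound above or below it.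

Compound 4, `Cc1ccc(-c2nc(NCCNc3ccc([N+](=O)[O-])c(N)n3)ncc2-c2ncc[nH]2)c(Br)c1`, differs from compound 3 by 2-bromo-4-methylphenyl in place of 2-chloro-5-fluorophenyl on an aromatic carbon. For the measured compounds named here, no measured step touches this position; the only step measured, a step that the two limits leave unreadable from compound 1 to compound 2, sits elsewhere and is unreadable in size. With no evidence for a shift, compound 4 is expected to show a step that the limit leaves unreadable from compound 3 to compound 4, none beyond the scatter. Compound 4 is thus estimated at 1 h in this assay, within 0.4 h to 3 h, most likely reported again only as a limit.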

Compound 4, half-life: > 0.5 h
Compound 4 ended at the assay's limit; the forecaster's own chance of this, stated with the estimate: 70%; the middle value does not contradict the limit.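

The step between compound 3 and compound 4 cannot be read, since each compound gives only a limit in this assay: the limit of > 0.5 h in this assay, at which 4 of the 4 values shown sit.

The compounds shown leave open how long any of them actually lasts in this assay, and whether 2-bromo-4-methylphenyl and 2-chloro-5-fluorophenyl differ there at all.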